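Chloro in place of fluoro on the urea phenyl ring

A few compounds are considered here, and "the series" means these few. Any claim that something is new, unique, unknown or untested is made for them only; others in the source may bear on it.

Compound 1 `CCN(CC)CCCNc1nc(-c2ccc(NC(=O)Nc3ccccc3)cc2)nc2ccsc12` gives 1230 nM in a functional assay on MDA-MB-231 cells (Homo sapiens) for cytotoxicity, read by MTT assay, with a stated time of 72 h (a higher number here means a weaker inhibitor, a lower number a stronger inhibitor), and compound 2 `CCN(CC)CCCNc1nc(-c2ccc(NC(=O)Nc3ccccc3F)cc2)nc2ccsc12` gives 860 nM. Among the measured compounds shown here, the only step measured so far, a 1.4-fold lower number from compound 1 to compound 2 (0.16 log units; within the scatter), is a change of fluoro for hydrogen on an aromatic carbon. Compound 2 thus has the smaller of the two numbers, but the two values lie within the scatter of each other, so neither compound can be called the stronger inhibitor.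

Compound 3 `CCN(CC)CCCNc1nc(-c2ccc(NC(=O)Nc3ccccc3Cl)cc2)nc2ccsc12` differs from compound 2 by chloro in place of fluoro on an aromatic carbon. For the measured compounds named here, the one measured step that bears on this change is a 1.4-fold lower number from compound 1 to compound 2 (0.16 log units; within the scatter), which touched the same aromatic carbon and stayed within the scatter. With nothing beyond that single, small step to go on, the expected step from fluoro to chloro, a 1.2-fold lower number from compound 2 to compound 3 (0.09 log units; within the scatter), is likewise a small one, expected to lie within the scatter rather than to change the picture. Compound 3 is therefore estimated at 700 nM, with a range from 300 nM to 1700 nM.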

Compound 3, half-maximal inhibitory concentration: 500 nM
Compound 3: middle estimate off by 1.4-fold (0.15 log units), on the high side; measured number inside the range.
By their numbers in this assay, from the lowest: compounds 3, 2 and 1 (each within the scatter of the next, the first and the last beyond it).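

Among the compounds shown here, at this aromatic carbon, ortho to a large group, a substituent now gives a step beyond the scatter for the first time in this assay: chloro in place of hydrogen gives a 2.5-fold lower number from compound 1 to compound 3 (0.39 log units; beyond the scatter) and so a modest difference from the unsubstituted phenyl urea. Chloro in place of fluoro gives a 1.7-fold lower number from compound 2 to compound 3 (0.24 log units; within the scatter) and so does not separate the two halogens, which means that compound 3 cannot be called a stronger inhibitor than compound 2, and the series shows a clear difference only between its two ends. No measurement is available that accounts for the step from hydrogen to chloro.

Going by these compounds, it remains open whether bromo, methyl or methoxy on the same carbon would stay close to chloro or move further from hydrogen, and whether chloro would give a step of similar size on another carbon of the phenyl ring. On these data alone, it is equally open how far this small difference would hold if the diethylamino group at the end of the side chain gave way to a morpholine or a piperidine.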